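A few compounds are considered here, and "the series" means these few. Any claim that something is new, unique, unknown or untested is made for them only; others in the source may bear on it.

The three compounds with measured numbers:

Compound 1, `Cc1nn2c(-c3nc4ccccc4[nH]3)c(-c3ccccc3)nc2s1`, gives 19900 nM.
Compound 2, `Cc1ccc(-c2nc3sc(C)nn3c2-c2nc3cc(Cl)ccc3[nH]2)cc1`, gives 5010 nM.
Compound 3, `Cc1nn2c(-c3nc4ccccc4[nH]3)c(-c3ccc(F)cc3)nc2s1`, gives 22200 nM.

These values come from a functional assay on A-375 cells (Homo sapiens) for antiproliferative activity, read by MTT assay; on this read-out lower numbers stand for stronger inhibition and higher numbers for weaker inhibition. Compound 2 has the lowest number of the three, and the gap to each of the other two is beyond the scatter. The difference between the core of compound 2 and the core of compound 1 is not broken down here.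

Compound 1 and compound 3 differ in one place, (fluoro in place of hydrogen on an aromatic carbon). This change gave a 1.1-fold higher number from compound 1 to compound 3 (0.05 log units; within the scatter), so it made no difference that can be told from the scatter.

The compound still to be measured is compound 4, `Cc1ccc(-c2nc3sc(C)nn3c2-c2nc3cc(Cl)c(F)cc3[nH]2)cc1`. It differs from compound 2 in one place, (fluoro in place of hydrogen on an aromatic carbon). Among the compounds with values here, this is the same kind of change as the one from compound 1 to compound 3, but not the same: in compound 3 the fluoro sits on a ring of carbon only, para to a large group, whereas in compound 4 it sits on a ring that is part of a fused system of two rings, ortho to a chloro group, meta to a fused ring and para to a fused ring. Within the data shown here, only one measured example of this kind of change exists here, and it sat in a different surrounding.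

For compound 4 in this assay the expected step is a 1.1-fold higher number from compound 2 to compound 4 (0.04 log units; within the scatter), a small one, because a 1.1-fold higher number from compound 1 to compound 3 (0.05 log units; within the scatter) stayed within the scatter. Compound 4 is expected to give about 5500 nM, with a range from 2500 nM to 12000 nM.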

Compound 4, half-maximal inhibitory concentration: 1040 nM
Estimate against measurement, compound 4: 5.3-fold (0.72 log units) above; the whole stated range lies above it.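

In this assay, fluoro in place of hydrogen gave a 4.8-fold lower number from compound 2 to compound 4 (0.68 log units; beyond the scatter), and this step does not match the one seen earlier on the other core: the same change on two cores in this assay, a 1.1-fold higher number (0.05 log units; within the scatter) from compound 1 to compound 3 and a 4.8-fold lower number (0.68 log units; beyond the scatter) from compound 2 to compound 4, 5.4-fold (0.73 log units) apart, beyond the scatter of two such steps. So in this series the result of this change did not carry over from one core to the other, and a step measured on the core of compound 1 proved a poor guide to the step on the core of compound 2. What these two pairs do not show is why the steps differ: the fluoro sits on a different ring in each pair and the surroundings differ in more than one way, so the place of the fluoro cannot be separated from the rest of the core, and nothing here tells what the change would do on a third core.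

The compounds shown leave open whether the fluoro of compound 4 would give a similar step without the chloro group on the same ring. They also leave open whether the step belongs to fluoro in particular, or whether a methoxy group, a nitrile or an amine on that same aromatic carbon would shift the number in the same way.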